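A few compounds are considered here, and "the series" means these few. Any claim that something is new, unique, unknown or untested is made for them only; others in the source may bear on it.

Compound 1 `COC1=C(C)C(=O)/C(=C(O)/C=C/c2ccc(Br)cc2)C(=O)C1(C)C`: 9 ug/mL
Compound 2 `CCc1ccc(/C=C/C(O)=C2/C(=O)C(C)=C(OC)C(C)(C)C2=O)cc1`: 12 ug/mL

Among the compounds with values here, in a functional assay on A-431 cells (Homo sapiens) for cytotoxicity (a lower number here means that less compound is needed, a higher number that more compound is needed for the effect), compound 2 gives 12 ug/mL, level with the only other measured compound. Compound 3 `COC1=C(C)C(=O)/C(=C(O)/C=C/c2c(C)cccc2C)C(=O)C1(C)C` is the next to consider: 2,6-dimethylphenyl in place of 4-ethylphenyl on a double-bonded chain carbon bound to a double-bonded chain carbon. This puts 2,6-dimethylphenyl in place of 4-ethylphenyl on a double-bonded chain carbon bound to a double-bonded chain carbon. Within the data shown here, the one measured step, an ethyl in place of a bromo, was small: a 1.3-fold higher number from compound 1 to compound 2 (0.12 log units; within the scatter), within the scatter. Among the measured compounds shown here, no measured compound carries 2,6-dimethylphenyl, so the guide is weak and no change beyond the scatter is expected. The expected step is no change at the digits printed from compound 2 to compound 3 (within the scatter). Compound 3 is estimated at 12 ug/mL, with an expected range of 5 ug/mL to 28 ug/mL.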

Compound 3, concentration for half-maximal effect: 10.1 ug/mL
Compound 3: middle estimate off by 1.2-fold (0.07 log units), on the high side; low and high end bracket the measured number.
By their numbers in this assay, from the lowest: compounds 1, 3 and 2 (each within the scatter of the next).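

In this assay, swapping 4-ethylphenyl for 2,6-dimethylphenyl gives a 1.2-fold lower number from compound 2 to compound 3 (0.07 log units; within the scatter) and swapping 4-bromophenyl for it gives a 1.1-fold higher number from compound 1 to compound 3 (0.05 log units; within the scatter) on the same double-bonded chain carbon. At this position, then, the three aromatic groups cannot be told apart, even with the ring substituents placed differently. Nothing measured here offers a reason for this.

On these data alone, whether an amine or a carboxylic acid on the aromatic ring would shift the number remains open. So does the effect of a longer chain in place of the ring.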